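The compounds below may be only part of what the source reports. "The series", "measured", "known", "first", "only" and "open" are said of these compounds alone.

In a functional assay on the whole organism (strain Wistar) for inhibition, with Rattus norvegicus as the target, read by paw edema, with stated times of 60 min and 2 h, at a dose of 100 mg/kg by the oral route (on this read-out higher numbers stand for more inhibition at the one dose given (going by the name of the read-out) and lower numbers for less inhibition), the measured compounds gave these numbers:

compound 1, `CCNC(=O)CC1CCc2cc(OC)c(OC)cc21`: 26%
compound 2, `COc1cc2c(cc1OC)C(CC(=O)NC(C)C)CC2`: 37%
compound 3, `CCCCCNC(=O)CC1CCc2cc(OC)c(OC)cc21`: 34%

Compound 1 and compound 3 differ in their cores by propyl in place of hydrogen on a saturated chain carbon, two bonds along the chain from an amide-type nitrogen, and this gives a number 8 percentage points higher from compound 1 to compound 3 (within the scatter). From compound 1 to compound 2 the change is methyl in place of hydrogen on a saturated chain carbon bound to an amide-type nitrogen and a saturated chain carbon, which gives a number 11 percentage points higher from compound 1 to compound 2 (beyond the scatter). Compound 2 and compound 3 differ in a further way, and this gives a number 3 percentage points lower from compound 2 to compound 3 (within the scatter).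

Compound 4, `CCCCCCNC(=O)CC1CCc2cc(OC)c(OC)cc21`, has not yet been measured. It differs from compound 3 by methyl in place of hydrogen on a saturated chain carbon, five bonds along the chain from an amide-type nitrogen. Going by the values given here, this is the same kind of change as the one from compound 1 to compound 2, but not at the same place: there the methyl enters on a saturated chain carbon bound to an amide-type nitrogen and a saturated chain carbon, here on a saturated chain carbon five bonds along the chain from an amide-type nitrogen. Beside the earlier step, a smaller step is expected for compound 4, a number 2 percentage points higher from compound 3 to compound 4 (within the scatter), because a number 3 percentage points lower from compound 2 to compound 3 (within the scatter) and a number 8 percentage points higher from compound 1 to compound 3 (within the scatter) both stayed within the scatter. In this assay compound 4 is therefore expected to give 36%, most likely between 22% and 50%.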

Compound 4, a percentage reported as inhibition, in the whole organism at one dose (the size of the read-out at that dose, not a potency): 41.5%
Estimate against measurement, compound 4: 5.5 percentage points below; low and high end bracket the measured number.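

Set side by side in this assay, the two methyl steps do not differ, so this change carries from one core to the other as far as two cases can tell: the same change on two cores in this assay, a number 11 percentage points higher (beyond the scatter) from compound 1 to compound 2 and a number 7.5 percentage points higher (within the scatter) from compound 3 to compound 4, 3.5 percentage points apart, within the scatter of two such steps. This does not show that the methyl itself raises the number on every core, since the step seen alone, a number 7.5 percentage points higher from compound 3 to compound 4 (within the scatter), cannot be told from repeat-measurement noise, and the methyl also enters at different places in the two pairs. Longer reaches give mixed readings: hexyl in place of isopropyl gives a number 4.5 percentage points higher from compound 2 to compound 4 (within the scatter), while butyl in place of hydrogen, the sum of more than one added carbon, gives a number 15.5 percentage points higher from compound 1 to compound 4 (beyond the scatter), the only one of these new steps that clears the scatter.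

The compounds shown leave open how a chain longer than hexyl on the amide nitrogen would read in this assay. They also leave open what an amine or a carboxylic acid carried on that chain would do.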